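The compounds below may be only part of what the source reports. "The series", "measured", "known", "first", "only" and "open" are said of these compounds alone.

Going by the values given here, compound 1 `Cc1csc(N/C(S)=N/[C@@H](C)c2cccc3ccccc23)n1` is the weaker of the two compounds measured in a functional assay on RBL-2H3 cells (Rattus norvegicus) for inhibition; on this read-out higher numbers stand for weaker inhibition and lower numbers for stronger inhibition: compound 1 gives 83200 nM, whereas compound 2 `Cc1cccc(N/C(S)=N/[C@@H](C)c2cccc3ccccc23)n1` gives 1600 nM, the only measured step being a 52-fold lower number from compound 1 to compound 2 (1.72 log units; beyond the scatter). Compound 3 `Cc1csc(N/C(S)=N/[C@H](C)c2cccc3ccccc23)n1` differs from compound 1 in a different way: the two compounds have the same atoms and bonds and differ only in configuration as drawn: 1 of 2 stereo elements differ; a stereocentre at a saturated chain carbon is drawn S in compound 1 and R in compound 3. Among the compounds with values here, that ring swap tells nothing about a change of configuration alone, so no measured step bears on this one, and the direction of the effect is unknown. Compound 3 is therefore expected to lie close to compound 1, with a step of about a 1.4-fold lower number from compound 1 to compound 3 (0.14 log units; within the scatter), at an estimated 60000 nM within a wide range of 8000 nM to 300000 nM.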

Compound 3, half-maximal inhibitory concentration: 25900 nM
Estimate against measurement, compound 3: 2.3-fold (0.36 log units) above; the range from low to high includes it.
By their numbers in this assay, from the lowest: compound 2; then compound 3; then compound 1.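

Changing the stereocentre at the saturated chain carbon from S to R gives a 3.2-fold lower number from compound 1 to compound 3 (0.51 log units; beyond the scatter), so in this assay the spatial arrangement at this position matters on its own, not only the ring group changed earlier. The gain is modest, and it can be assigned to this stereocentre alone because nothing else changes: the fact that compounds 1 and 3 differ only in the configuration as drawn

On these data alone, whether the R form would also be favoured with the 6-methylpyridin-2-yl group of compound 2 remains open. So does the effect of an ethyl group in place of the methyl on this stereocentre.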